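Sulfonyl side-chain variation and microsomal stability

This account rests on a few compounds, and the source may have more. Where it says the series, first, only, none or still open, it means among the compounds named here.

Three compounds share one core and differ only in the group on the sulfonyl sulfur. Compound 1 `CNC(=O)NCCS(=O)(=O)NC(=O)c1ccc(Nc2nc(NC3(c4ccc(Cl)cc4)CC3)nc(OCC(F)(F)F)n2)cc1` gives 97% in an ADME assay on microsomes from liver (Homo sapiens) for metabolic stability, with a stated time of 10 min; a lower number here means that less of the compound is left, a higher number that more of the compound is left. Compound 2 `O=C(NS(=O)(=O)c1ccc(F)cc1)c1ccc(Nc2nc(NC3(c4ccc(Cl)cc4)CC3)nc(OCC(F)(F)F)n2)cc1` gives 100% in this assay. Compound 3 `O=C(NS(=O)(=O)CCNC(=O)C1CC1)c1ccc(Nc2nc(NC3(c4ccc(Cl)cc4)CC3)nc(OCC(F)(F)F)n2)cc1` gives 90% in this assay. All three figures lie within the scatter of one another: a number 3 percentage points higher from compound 1 to compound 2 (within the scatter), a number 7 percentage points lower from compound 1 to compound 3 (within the scatter), a number 10 percentage points lower from compound 2 to compound 3 (within the scatter). Compound 3 therefore stands together with compounds 1 and 2, not separated from either.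

Compound 4 `O=C(NS(=O)(=O)CCNCc1ccccc1)c1ccc(Nc2nc(NC3(c4ccc(Cl)cc4)CC3)nc(OCC(F)(F)F)n2)cc1` is not yet measured. Relative to compound 3 the change is benzyl in place of cyclopropylcarbonyl on an amine nitrogen.

Among the measured compounds shown here, the steps that bear on this are the earlier changes on the same chain and at the same position on the sulfonyl sulfur, a number 7 percentage points lower from compound 1 to compound 3 (within the scatter) and a number 10 percentage points lower from compound 2 to compound 3 (within the scatter), both within the scatter. The data give no step beyond the scatter for any variation at this position, so the expected step of no change at the digits printed from compound 3 to compound 4 (within the scatter) is none beyond the scatter. Compound 4 is estimated at 90%, with a range from 75% to 100%.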

Compound 4, percent of the compound remaining: 99%
Estimate against measurement, compound 4: 9 percentage points below; measured number inside the range.
By their numbers in this assay, from the lowest: compounds 3, 1, 4 and 2 (each within the scatter of the next).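

Among the compounds shown here, the first non-acyl group on this amine nitrogen stands with the acylated chains in this assay: benzyl in place of cyclopropylcarbonyl gives a number 9 percentage points higher from compound 3 to compound 4 (within the scatter) and benzyl in place of methylcarbamoyl gives a number 2 percentage points higher from compound 1 to compound 4 (within the scatter). A basic count of the change shows an aromatic ring entering and the carbonyl leaving, and neither moves the figure beyond the scatter; the 2-(benzylamino)ethyl chain also stands with the 4-fluorophenyl group on the sulfonyl sulfur, with a number 1 percentage points lower from compound 2 to compound 4 (within the scatter). Nothing measured on these compounds explains why the four figures lie together.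

On these data alone, whether any group at this position gives a step beyond the scatter remains open. A free primary amine, a carboxylic acid or a longer chain between the sulfonyl sulfur and the amine nitrogen would test this.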